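The compounds below may be only part of what the source reports. "The series", "measured", "known", "first", "only" and "open" are said of these compounds alone.

Compound 1 `COC(=O)[C@H](CCSC)NC(=O)c1ccc(OC[C@@H]2COc3ccccc3O2)cc1-c1ccccc1C` and compound 2 `COC(=O)[C@H](CCSC)NC(=O)c1ccc(OC[C@@H]2COc3ccccc3O2)cc1-c1ccccc1OC` share one core. In a functional assay (HSMC cells, Homo sapiens) for antiproliferative activity, with a stated time of 72 h (on this read-out lower numbers stand for stronger inhibition and higher numbers for weaker inhibition), compound 1 gives 193000 nM and compound 2 gives 204000 nM. The change between them, (methoxy in place of methyl on an aromatic carbon), made a 1.1-fold higher number from compound 1 to compound 2 (0.02 log units; within the scatter). Compound 3 `COC(=O)CNC(=O)c1ccc(C(=O)NC[C@H]2COc3ccccc3O2)cc1-c1ccccc1C` carries a different core; the difference between the two cores is not broken down here. In this assay compound 3 gives 113000 nM; its values against compound 1 and compound 2 all lie within the scatter, so no order among the three is drawn. Compound 4 `COC(=O)CNC(=O)c1ccc(C(=O)NC[C@H]2COc3ccccc3O2)cc1-c1ccccc1OC` differs from compound 3 by methoxy in place of methyl on an aromatic carbon, the same change as from compound 1 to compound 2, at a place described in the same words. The step of a 1.1-fold higher number from compound 3 to compound 4 (0.04 log units; within the scatter) is expected, resting on a 1.1-fold higher number from compound 1 to compound 2 (0.02 log units; within the scatter). For compound 4 the estimate is 125000 nM, expected to fall between 60000 nM and 260000 nM.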

Compound 4, half-maximal inhibitory concentration: 122000 nM
Beside the measured number, compound 4's estimate is 1.0-fold (0.01 log units) above it; low and high end bracket the measured number.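

In this assay, methoxy in place of methyl on an aromatic carbon made a 1.1-fold higher number from compound 3 to compound 4 (0.03 log units; within the scatter). Set beside the earlier step, the change carries from one core to the other with no visible difference: the same change on two cores in this assay, a 1.1-fold higher number (0.02 log units; within the scatter) from compound 1 to compound 2 and a 1.1-fold higher number (0.03 log units; within the scatter) from compound 3 to compound 4, 1.0-fold (0.01 log units) apart, within the scatter of two such steps Both steps lie within the scatter, so this is agreement between two steps too small to read, and it does not show that a step of real size would carry across, or that the change would behave alike on any further core.

Open, going by these compounds, is whether another group at this place, such as an amine, a carboxylic acid or a trifluoromethyl, would give a step beyond the scatter on either core. Also open, on these data alone, is the contribution of each difference between the two cores.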